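Ring size at the aminomethyl substituent: pyrrolidine to piperidine

A few compounds are considered here, and "the series" means these few. Any claim that something is new, unique, unknown or untested is made for them only; others in the source may bear on it.

Measured compounds:
- compound 1, `Cc1cc(=O)c2c(O)cc(OCc3ccc([N+](=O)[O-])cc3)c([C@H]3CCN(C)C[C@H]3O)c2o1`: 14%
- compound 2, `Cc1cc(=O)c2c(O)cc(OCc3ccco3)c([C@H]3CCN(C)C[C@H]3O)c2o1`: 17%
- compound 3, `Cc1cc(=O)c2c(O)c(CN3CCCC3)c(O)c([C@H]3CCN(C)C[C@H]3O)c2o1`: 22%

All three share a core and were tested in a functional assay on Caco-2 cells (Homo sapiens) for inhibition, read by MTT assay, with a stated time of 48 h, tested at 10 uM; a lower number here means less inhibition of growth, a higher number more inhibition of growth at the concentration tested. Compound 3 gives the largest of the three numbers, but the gap to compound 2 and the gap to compound 1 both lie within the scatter, so no order among the three can be read from these values. Among the measured compounds shown here, the only step between compounds differing in one place is a number 3 percentage points higher from compound 1 to compound 2 (within the scatter), and it concerns a different position of the core.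

Compound 4, `Cc1cc(=O)c2c(O)c(CN3CCCCC3)c(O)c([C@H]3CCN(C)C[C@H]3O)c2o1`, has not been measured. Compared with compound 3 it carries piperidin-1-yl in place of pyrrolidin-1-yl on a saturated chain carbon bound to an aromatic carbon. For the measured compounds named here, no measured pair in this set changes the (pyrrolidin-1-yl)methyl group, and the one step available, from compound 1 to compound 2, was itself within the scatter. There is therefore nothing in the data to support a step beyond the scatter in this assay for this change, in either direction. The expected step is no change at the digits printed from compound 3 to compound 4 (within the scatter), i.e. essentially none. Compound 4 is estimated at 22%, with a range from 10% to 34%.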

Compound 4, percent growth inhibition at one concentration: 22%
The estimate for compound 4 equals the measured number at the digits printed; the measured number falls inside the stated range.
By their numbers in this assay, from the lowest: compounds 1, 2, 3 and 4 (each within the scatter of the next).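

In this assay, among the compounds shown here, the pair at the saturated chain carbon bound to an aromatic carbon gives no change at the digits printed from compound 3 to compound 4 (within the scatter) and thus provides the first reading at this position, since the only earlier step concerned a saturated chain carbon bound to an oxygen on an aromatic ring. Within this pair, a six-membered non-aromatic ring in place of a five-membered one, with the nitrogen attachment kept, does not separate the two compounds at the concentration tested. No available evidence bears on this result.

Going by these compounds, whether a morpholin-4-yl or dimethylamino group at this place, or a longer chain carrying the piperidin-1-yl group, would give a step beyond the scatter remains open. The pair also leaves open whether the same exchange would read alike on a core carrying other groups.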